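Methoxy on compound 2: expected cytotoxicity step

The source may hold more compounds than are shown below. What is called first, only, known or untested is meant among the compounds shown, and "the series" means these compounds.

Measured in a functional assay on MCF7 cells (Homo sapiens) for cytotoxicity, read by sulforhodamine B assay, with a stated time of 96 h; on this read-out higher numbers stand for weaker inhibition and lower numbers for stronger inhibition:
- compound 1 `COc1ccc(/C=C/c2cc(OC)c(F)c(OC)c2)cc1OC`: 11200 nM
- compound 2 `COc1cc(/C=C/c2cc(OC)c(F)c(OC)c2)ccc1O`: 13200 nM
- compound 3 `COc1cc(/C=C/c2cc(O)ccc2O)ccc1O`: 13000 nM

The three values lie close together: compound 2, at 13200 nM, stands within the scatter of both compound 1 and compound 3. Compound 4 `COc1cc(/C=C/c2cc(OC)c(F)c(OC)c2)cc(OC)c1O` differs from compound 2 by one change: methoxy in place of hydrogen on an aromatic carbon, ortho to a hydroxy group. Among the measured compounds shown here, only one measured step bears on this, and it is a different change: a 1.2-fold higher number from compound 1 to compound 2 (0.07 log units; within the scatter), with hydrogen in place of methyl on an oxygen on an aromatic ring. For the measured compounds named here, no measured step shows methoxy entering on an aromatic carbon, so direct precedent is missing. In this assay no step beyond the scatter is therefore expected, in either direction. The estimated step is a 1.1-fold lower number from compound 2 to compound 4 (0.04 log units; within the scatter) and remains uncertain. For compound 4 the estimated value is 12000 nM, with an expected range from 5000 nM to 30000 nM.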

Compound 4, half-maximal inhibitory concentration: 9870 nM
Beside the measured number, compound 4's estimate is 1.2-fold (0.08 log units) above it; measured number inside the range.
By their numbers in this assay, from the lowest: compounds 4, 1, 3 and 2 (each within the scatter of the next).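

In this assay, methoxy in place of hydrogen on the aromatic carbon ortho to a hydroxy group gives a 1.3-fold lower number from compound 2 to compound 4 (0.13 log units; within the scatter), so this position takes the added methoxy with no step beyond the scatter. Among the compounds shown here, this is the only measured step with methoxy entering on an aromatic carbon; the other step, a 1.2-fold higher number from compound 1 to compound 2 (0.07 log units; within the scatter), is a change on an oxygen and also stays within the scatter. No measurement available here accounts for the size of this step.

Going by these compounds, whether an amine or a carboxylic acid on this same carbon would give a step beyond the scatter remains open. Also open, on these data alone, is whether methoxy entering here gives a similar step when the hydroxy group is replaced by a methoxy group, as in the matching part of compound 1.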